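Methoxy in Place of Trifluoromethyl on the Distal Ring

A few compounds are considered here, and "the series" means these few. Any claim that something is new, unique, unknown or untested is made for them only; others in the source may bear on it.

Compound 1 `O=C(O)CS(=O)(=O)c1ccc(OCc2cccc(-c3ccccc3Cl)c2)cc1` and compound 2 `O=C(O)CS(=O)(=O)c1ccc(OCc2cccc(-c3ccccc3C(F)(F)F)c2)cc1` share one core. In a functional assay on CHO cells for agonist activity at Free fatty acid receptor 1 (Homo sapiens), read by FLIPR and calcium flux (a higher number here means that more compound is needed for the effect, a lower number that less compound is needed), compound 1 gives 28.8 nM, and compound 2 gives 52.5 nM. Compound 2 holds the higher of the two numbers, yet the step is small: a 1.8-fold higher number from compound 1 to compound 2 (0.26 log units; within the scatter). Compound 3 `COc1ccccc1-c1cccc(COc2ccc(S(=O)(=O)CC(=O)O)cc2)c1` carries methoxy in place of trifluoromethyl on an aromatic carbon. Among the compounds with values here, only the step from compound 1 to compound 2 bears on this change, and it stayed within the scatter, so for compound 3 no step beyond the scatter is expected, a 1.3-fold lower number from compound 2 to compound 3 (0.12 log units; within the scatter). For compound 3 the estimated value in this assay is 40 nM, between 15 nM and 120 nM.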

Compound 3, half-maximal effective concentration: 195 nM
For compound 3 the middle estimate is 4.9-fold (0.69 log units) below the measured one, outside the stated range (above it).
By their numbers in this assay, from the lowest: compounds 1 and 2 (each within the scatter of the next); then compound 3.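

In this assay, replacing trifluoromethyl with methoxy gives a 3.7-fold higher number from compound 2 to compound 3 (0.57 log units; beyond the scatter) and replacing chloro with methoxy gives a 6.8-fold higher number from compound 1 to compound 3 (0.83 log units; beyond the scatter) so this position does respond to its substituent, though the exchange of chloro for trifluoromethyl stayed within the scatter. Among these three compounds, methoxy alone stands apart, while chloro and trifluoromethyl cannot be told apart. No measurement at hand accounts for the difference. The compounds shown leave open how a hydroxyl, an ethoxy or an amine would read at this position.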